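Arylsulfonamide in place of benzylsulfonamide on a chromene core

The source may report more compounds than this note shows. Statements on the series, on what has been measured and on what is new or still open speak of the compounds shown alone.

Measured compounds:
compound 1 `CC1(C)C=C(n2ccccc2=O)c2cc(S(=O)(=O)NCc3ccccc3)ccc2O1`: 525 nM
compound 2 `CC1(C)C=C(n2ccccc2=O)c2cc(S(=O)(=O)Nc3ccccc3)ccc2O1`: 3.09 nM; 2 nM (2 entries)

In a functional assay with Rattus norvegicus as the target (on this read-out higher numbers stand for an effect only at larger amounts of compound and lower numbers for an effect already at smaller amounts), compound 1 gives 525 nM, the only number shown for it; a further entry gives no single number. Compound 2, which carries a phenyl rather than a benzyl on the sulfonamide nitrogen, gives 3.09 nM; 2 nM (2 entries) in this assay, and the several entries of compound 2 in this assay, 3.09 nM; 2 nM (2 entries) shows these repeat entries agree with each other.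

Compound 3 `CC1(C)C=C(n2ccccc2=O)c2cc(S(=O)(=O)Nc3ccc([N+](=O)[O-])cc3)ccc2O1` is not yet measured. The change from compound 1 is 4-nitrophenyl in place of benzyl on a sulfonamide nitrogen. Going by the values given here, no step between measured compounds is available for this change. Because compound 2 reaches 3.09 nM; 2 nM (2 entries) with an aryl directly on the sulfonamide nitrogen, compound 3 is expected to move well beyond the scatter in the direction of smaller amounts. The step of a 53-fold lower number from compound 1 to compound 3 (1.72 log units; beyond the scatter) is the expected size of that move. Compound 3 is estimated at 10 nM, within 2 nM to 80 nM.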

Compound 3, half-maximal effective concentration: 2090 nM
Compound 3: middle estimate off by 210-fold (2.32 log units), on the low side; the whole stated range lies below it.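

In this assay, 4-nitrophenyl in place of benzyl gives a 4.0-fold higher number from compound 1 to compound 3 (0.60 log units; beyond the scatter), so an aryl group directly on the sulfonamide nitrogen does not by itself bring the number down. Phenyl and 4-nitrophenyl on that nitrogen lie far apart, with compound 2 at 3.09 nM; 2 nM (2 entries) and compound 3 at 2090 nM, which shows that this position responds strongly to what the aryl ring carries. The low number of compound 2 is not a single stray reading, as its repeat entries agree: the several entries of compound 2 in this assay, 3.09 nM; 2 nM (2 entries)

As far as these compounds go, whether a 4-aminophenyl or a 4-methoxyphenyl on the sulfonamide nitrogen would fall nearer compound 2 or compound 3 remains open. Also open is what lies behind the gap between phenyl and 4-nitrophenyl, as the compounds shown offer no measured property that would explain it.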